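Series notes: substitution at the ring carbon between two nitrogens

The compounds below may be only part of what the source reports. "The series", "measured", "known", "first", "only" and "open" are said of these compounds alone.

Measured compounds:
- compound 1, `Nc1nc(O)nc2c1nc(O)n2Cc1ccccc1`, 0.1 uM
- compound 2, `Nc1ncnc2c1nc(O)n2Cc1ccccc1`, 10 uM
- compound 3, `CCNc1nc(N)c2nc(O)n(Cc3ccccc3)c2n1`, 1 uM

All three were tested in a functional assay (spleen, spleen) for activation, with Mus musculus as the target; a lower number here means that less compound is needed, a higher number that more compound is needed for the effect. Compound 3 gives the second highest of the three numbers; its nearest neighbour is compound 1 and its furthest is compound 2. The measured steps show how sensitive this carbon is: a 100-fold higher number from compound 1 to compound 2 (2.00 log units; beyond the scatter), a 10-fold higher number from compound 1 to compound 3 (1.00 log units; beyond the scatter), and a 10-fold lower number from compound 2 to compound 3 (1.00 log units; beyond the scatter).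

Compound 4, `CCCC[S+]([O-])c1nc(N)c2nc(O)n(Cc3ccccc3)c2n1`, is not yet measured. It differs from compound 3 only here: a group of 6 heavy atoms (4 carbon, 1 oxygen, 1 sulfur; no ring) in place of a group of 3 heavy atoms (2 carbon, 1 nitrogen; no ring), on an aromatic carbon. For the measured compounds named here, no measured step involves the entering group, so none bears directly on it; the steps from compound 1 and compound 2 to compound 3 show only that swapping this group can move the number by a modest to large amount in either direction. A donor-free group replacing ethylamino is expected to cost somewhat, so for compound 4 the estimated step is a 3.0-fold higher number from compound 3 to compound 4 (0.48 log units; beyond the scatter), and the expected value is 3 uM, within a range from 0.3 uM to 30 uM.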

Compound 4, minimum effective concentration: 0.01 uM
For compound 4 the middle estimate is 300-fold (2.48 log units) above the measured one; measured number below the stated range.
By their numbers in this assay, from the lowest: compound 4; then compound 1; then compound 3; then compound 2.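

In this assay, the entering group of 6 heavy atoms (4 carbon, 1 oxygen, 1 sulfur) gives the lowest number of the four compounds: a 100-fold lower number from compound 3 to compound 4 (2.00 log units; beyond the scatter), a 1000-fold lower number from compound 2 to compound 4 (3.00 log units; beyond the scatter), and a 10-fold lower number from compound 1 to compound 4 (1.00 log units; beyond the scatter). With 0 hydrogen-bond donors in this group, a donor on this aromatic carbon is not required for a low number, and hydroxy, which gave the lowest number among the first three compounds, does not mark the limit at this position. No measured evidence accounts for this gain.

The compounds shown leave open whether the gain follows the sulfur and oxygen atoms or the length of the chain, since the entering group differs from ethylamino in both. A butylamino group, or an ethyl chain carried on the same sulfur and oxygen, would separate the two.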